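The source may report more compounds than this note shows. Statements on the series, on what has been measured and on what is new or still open speak of the compounds shown alone.

Measured compounds:
compound 1, `COc1ccc(-c2c[nH]c(=O)n2-c2cc(OC)c(OC)c(OC)c2)cc1` — > 50000 nM
compound 2, `COc1ccc(-c2c[nH]c(=O)n2-c2cc(OC)c(OC)c(OC)c2)cc1OC` — > 50000 nM
compound 3, `COc1ccc(-c2cn(C(=O)Nc3cc(OC)c(OC)c(OC)c3)c(=O)n2-c2cc(OC)c(OC)c(OC)c2)cc1` — 49700 nM

In a functional assay on PC-3 cells (Homo sapiens) for cytotoxicity, read by MTT assay, with a stated time of 48 h (on this read-out higher numbers stand for weaker inhibition and lower numbers for stronger inhibition), compound 1 gives > 50000 nM, which is a limit of the assay and not a number. In this assay compound 2 gives > 50000 nM, likewise a limit. In this assay, for the measured compounds named here, compound 3 gives 49700 nM, the only number among the three.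

The change from compound 1 to compound 2 is methoxy in place of hydrogen on an aromatic carbon. The step it made, a step that the two limits leave unreadable from compound 1 to compound 2, cannot be read because the limit of > 50000 nM in this assay, at which 2 of the 3 values shown sit, covers both ends of it.

Compound 4, `COc1ccc(-c2cn(C(=O)Nc3cc(OC)c(OC)c(OC)c3)c(=O)n2-c2cc(OC)c(OC)c(OC)c2)cc1OC`, has not been measured. It differs from compound 3 by methoxy in place of hydrogen on an aromatic carbon. The surroundings of the place read the same as for the change from compound 1 to compound 2; cut one bond further out the change on compound 3 reads 4-methoxyphenyl to 3,4-dimethoxyphenyl, so this is the same kind of change made a second time, on a different core. The difference between the core of compound 1 and the core of compound 3 is not broken down here.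

Compound 3 gives 49700 nM, a weak value, and the earlier occurrence of the change gave no readable step, so compound 4 is expected to sit at about the same level. In this assay compound 4 is expected to give 50000 nM, with a likely range from 20000 nM to 120000 nM. The step expected is a 1.0-fold higher number from compound 3 to compound 4 (0.00 log units; within the scatter), and a limit rather than a number is the likelier report.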

Compound 4, half-maximal inhibitory concentration: > 50000 nM
Compound 4: a limit, no number (the forecaster's own chance of this, stated with the estimate: 65%); the middle value lies on the limit itself.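

In this assay compound 4 gives > 50000 nM, which is a limit of the assay and not a number. On the core of compound 3, methoxy in place of hydrogen on an aromatic carbon leaves a number no lower from compound 3 to compound 4 (the limit leaves the size open), so the change produces no measurable gain in inhibition on this core, and the size of the step cannot be read, just as on the core of compound 1. The two occurrences therefore agree only in giving no readable improvement, and they cannot show whether the change carries the same size of effect from one core to the other, because the values sit at one edge of the measurable range: the limit of > 50000 nM in this assay, at which 3 of the 4 values shown sit.

Still open, as far as these compounds go, is whether any compound of this series reaches a clearly measurable level in this assay, and how much the difference between the core of compound 1 and the core of compound 3 contributes, as that difference is not broken down. Also open, from the compounds shown here alone, is whether an amine, a carboxylic acid or a longer alkoxy chain in place of a methoxy on the 3,4-dimethoxyphenyl would move the read-out away from the limit.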